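This account rests on a few compounds, and the source may have more. Where it says the series, first, only, none or still open, it means among the compounds named here.

Compound 1 `COc1ccccc1/C=C1\CCC/C(=C\c2cccc(OC)c2OC)C1=O` is one of three close relatives tested in an ADME assay on NHDF cells (Homo sapiens) for cytotoxicity, read by MTT assay, with a stated time of 72 h (on this read-out lower numbers stand for stronger inhibition and higher numbers for weaker inhibition), where compound 1 gives 31300 nM. Of the two compounds that returned a number, compound 1 has the higher one; compound 3 `COc1cccc(/C=C2\CCC/C(=C\c3cc(OC)c(OC)c(OC)c3)C2=O)c1OC` gives 7900 nM, and that gap lies beyond the scatter. Compound 2 `COc1ccc(/C=C2\CCC/C(=C\c3cccc(OC)c3OC)C2=O)c(OC)c1` reaches only the limit of the assay, reported as > 50000 nM. The step of an at least 1.5-fold higher number from compound 1 to compound 2 (0.20 log units; that floor lies within the scatter) comes from a methoxy in place of hydrogen on an aromatic carbon and ends at the limit of > 50000 nM in this assay, at which 1 of the 3 values shown sits, so its true size cannot be read.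

Compound 4 `COc1cccc(/C=C2\CCC/C(=C\c3ccc(O)c(Cl)c3)C2=O)c1OC` alters compound 1 in another place: 3-chloro-4-hydroxyphenyl in place of 2-methoxyphenyl on a double-bonded chain carbon bound to a double-bonded ring carbon. For the measured compounds named here, no measured step swaps this whole aromatic group, so the measured steps only show that the numbers here spread over a modest range, with one at the limit. Compound 4 is therefore expected to stay near compound 1, with an estimated step of a 1.3-fold lower number from compound 1 to compound 4 (0.10 log units; within the scatter), not beyond the scatter. The estimate for compound 4 is 25000 nM, with a range from 8000 nM to 60000 nM.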

Compound 4, half-maximal inhibitory concentration: 39500 nM
The estimate for compound 4 lay 1.6-fold (0.20 log units) below the measured number, and the stated range covers the measured number.
By their numbers in this assay, from the lowest: compound 3; then compounds 1 and 4 (each within the scatter of the next). At a limit, above all of these: compound 2.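

Replacing the whole aromatic group on a double-bonded chain carbon bound to a double-bonded ring carbon, with 3-chloro-4-hydroxyphenyl taking the place of 2-methoxyphenyl, gives in this assay a 1.3-fold higher number from compound 1 to compound 4 (0.10 log units; within the scatter). Unlike the step ending at compound 2, this one has a readable size, and it shows that this position can take a different aromatic group, one that carries a chlorine and a hydrogen-bond donor, without moving the number beyond the scatter. Nothing measured here explains why so large a swap leaves the number within the scatter.

As far as these compounds go, what the chlorine and the hydroxy each contribute stays open, as they enter together in compound 4. Also open, from the compounds shown here alone, is how the number would respond to an amine or a carboxylic acid on this aromatic group.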